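Amino for chloro on two chromone cores

This account rests on a few compounds, and the source may have more. Where it says the series, first, only, none or still open, it means among the compounds named here.

Measured compounds:
Compound 1 `O=c1cc(-c2ccc(Cl)cc2)oc2ccc(CN3CCCCC3)cc12` — 14000 nM
Compound 2 `Nc1ccc(-c2cc(=O)c3cc(CN4CCCCC4)ccc3o2)cc1` — 2640 nM
Compound 3 `Cc1cc(Cl)cc2c(=O)cc(-c3ccc(Cl)cc3)oc12` — "not determined" (no result reported)

In a functional assay on HepG2 cells (Homo sapiens) for cytotoxicity, read by MTT assay, with a stated time of 48 h (a higher number here means a weaker inhibitor, a lower number a stronger inhibitor), compound 1 gives 14000 nM and compound 2 gives 2640 nM. Between them lies one change, (amino in place of chloro on an aromatic carbon), and that step reads a 5.3-fold lower number from compound 1 to compound 2 (0.72 log units; beyond the scatter).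

Compound 3 `Cc1cc(Cl)cc2c(=O)cc(-c3ccc(Cl)cc3)oc12` carries a different core; how its core differs from the core of compound 1 is not broken down here. In this assay compound 3 stands as "not determined" (no result reported), so no number is reported for it. Compound 4 `Cc1cc(Cl)cc2c(=O)cc(-c3ccc(N)cc3)oc12` is compound 3 with the same change made, (amino in place of chloro on an aromatic carbon), and the surroundings of the change are the same in both pairs, so it is the same change, seen here for the second time among the four compounds.

Among the measured compounds shown here, for compound 4 no step can be computed in this assay, since compound 3 has no value to step from. What can be said rests on compound 2, which in this assay gives 2640 nM, and on the step seen from compound 1 to compound 2, a 5.3-fold lower number from compound 1 to compound 2 (0.72 log units; beyond the scatter). Compound 4 is expected, with wide uncertainty given its untested core, to give about 5000 nM in this assay, estimated to lie between 1000 nM and 30000 nM.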

Compound 4, half-maximal inhibitory concentration: 11900 nM
Estimate against measurement, compound 4: 2.4-fold (0.38 log units) below, within the range that was stated.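

In this assay, among the compounds shown here, compound 3 stands as "not determined" (no result reported), so no step from it to compound 4 can be read. The compounds shown leave open whether amino in place of chloro on an aromatic carbon changes the number on the core of compound 3 as it does on the core of compound 1. No further data here bear on the result.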